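Replacing Fluoro with Pyrrolidin-1-yl: An Expected Step

The source may hold more compounds than are shown below. What is called first, only, known or untested is meant among the compounds shown, and "the series" means these compounds.

Measured so far in a functional assay on T47D cells (Homo sapiens) for cytotoxicity, read by MTT assay; a lower number here means a stronger inhibitor, a higher number a weaker inhibitor:
- compound 1 `O=C(/C=C/c1ccc(N2CCCC2)cc1)c1ccc(O)cc1`: 1370 nM
- compound 2 `O=C(/C=C/c1ccc(F)cc1)c1ccc(O)cc1O`: 8310 nM

Of the two numbers, compound 2 holds the higher, and the gap to compound 1 lies beyond the usual scatter. That makes compound 2 the weaker inhibitor of the pair in this assay.

Compound 3 `O=C(/C=C/c1ccc(N2CCCC2)cc1)c1ccc(O)cc1O` has not yet been measured. It carries pyrrolidin-1-yl in place of the fluoro of compound 2, on an aromatic carbon, para to a large group (pyrrolidin-1-yl in place of fluoro on an aromatic carbon).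

Within the data shown here, no measured pair shows this change directly, so any expectation is indirect. Among the measured compounds shown here, the only guide is compound 1, which also carries pyrrolidin-1-yl and gives 1370 nM. A step toward a lower number, beyond the scatter, is therefore expected in this assay.

The expected change is a 4.6-fold lower number from compound 2 to compound 3 (0.66 log units; beyond the scatter).

For compound 3 the estimated value is 1800 nM, with an expected range from 600 nM to 5000 nM.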

Compound 3, half-maximal inhibitory concentration: 6990 nM
The estimate for compound 3 lay 3.9-fold (0.59 log units) below the measured number, outside the stated range (above it).
By their numbers in this assay, from the lowest: compound 1; then compounds 3 and 2 (each within the scatter of the next).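

In this assay, pyrrolidin-1-yl in place of fluoro on an aromatic carbon, para to a large group, gives a 1.2-fold lower number from compound 2 to compound 3 (0.08 log units; within the scatter) and so does not separate the two compounds on this core. With pyrrolidin-1-yl held fixed, hydroxy in place of hydrogen on an aromatic carbon gives a 5.1-fold higher number from compound 1 to compound 3 (0.71 log units; beyond the scatter) and thus marks a change that does register here, so pyrrolidin-1-yl alone does not carry the low number of compound 1. Nothing measured here accounts for either step.

The compounds shown leave open whether the hydroxy step would hold with fluoro at the para carbon instead of pyrrolidin-1-yl. They also leave open how other groups at that carbon, such as a dimethylamino group, a piperidin-1-yl ring or a methoxy group, would compare on either core.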